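The source may hold more compounds than are shown below. What is called first, only, known or untested is meant among the compounds shown, and "the series" means these compounds.

Compound 2, `COc1ccc(CS(=O)(=O)/C=C/c2ccc(OC)c(OC)c2)cc1`, was tested in a functional assay on DLD-1 cells (Homo sapiens) for antiproliferative activity, read by trypan blue exclusion; a higher number here means a weaker inhibitor, a lower number a stronger inhibitor. In this assay compound 2 gives only a limit, > 20000 nM, so its true potency is not known. Compound 1, `COc1ccc(/C=C/S(=O)(=O)Cc2ccc(OC)cc2)cc1`, differs from compound 2 in a single group. In this assay compound 1 also gives only a limit, > 20000 nM. The step that the two limits leave unreadable from compound 1 to compound 2 therefore cannot be read, because of the limit of > 20000 nM in this assay, at which 2 of the 2 values shown sit.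

Compound 3, `COc1ccc(CS(=O)(=O)/C=C/c2cc(OC)c(OC)cc2OC)cc1`, is the next member. It carries the change (methoxy in place of hydrogen on an aromatic carbon), set on an aromatic carbon of a six-membered aromatic ring of carbon only. For the measured compounds named here, the only measured step of this kind, from compound 1 to compound 2, is unreadable, so the expected step that the limit leaves unreadable from compound 2 to compound 3 has no size or direction that can be claimed beyond the scatter, and the assay will most likely once more report a limit. Compound 3 is accordingly estimated at 30000 nM, within a range from 10000 nM to 100000 nM.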

Compound 3, half-maximal inhibitory concentration: > 20000 nM
Compound 3 gave a limit, no number; the forecaster's own chance of this, stated with the estimate: 70%; the middle value lies beyond the limit too.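

No size or direction can be read for the step from compound 2 to compound 3, and the limit reached by compound 3 is shared by all the compounds shown: the limit of > 20000 nM in this assay, at which 3 of the 3 values shown sit. Going by these compounds, the true potencies of compound 1, compound 2 and compound 3 stay open, as does whether an added methoxy group changes potency in this assay.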